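This account rests on a few compounds, and the source may have more. Where it says the series, first, only, none or still open, it means among the compounds named here.

Compound 3 `CC(C(=O)NCc1ccc(C(F)(F)F)cc1OC1CCCC1)c1ccc(NS(C)(=O)=O)c(F)c1` gives 0.6 nM in an assay on CHO cells for antagonist activity at transient receptor potential cation channel subfamily V member 1 (Homo sapiens), read by FLIPR; a lower number here means a stronger inhibitor, a higher number a weaker inhibitor; among the three measured compounds it stands second highest, with compound 2 `CC(C)CCOc1cc(C(F)(F)F)ccc1CNC(=O)C(C)c1ccc(NS(C)(=O)=O)c(F)c1` nearest at 0.5 nM and compound 1 `CCCCN(C)c1cc(C(F)(F)F)ccc1CNC(=O)C(C)c1ccc(NS(C)(=O)=O)c(F)c1` furthest at 1.2 nM. Compound 4 `CC(C(=O)NCc1ccc(C(F)(F)F)cc1SCc1ccccc1)c1ccc(NS(C)(=O)=O)c(F)c1` differs from compound 3 at one place: benzylsulfanyl in place of cyclopentyloxy on an aromatic carbon. Two measured steps alter the same aromatic carbon: a 2.0-fold lower number from compound 1 to compound 3 (0.30 log units; within the scatter) and a 1.2-fold higher number from compound 2 to compound 3 (0.08 log units; within the scatter). Both of those swaps stay within the scatter. For compound 4 the step of a 1.7-fold higher number from compound 3 to compound 4 (0.22 log units; within the scatter) is therefore expected to be small in this assay, without a clear direction. For the measured compounds named here, no measured compound carries a benzylsulfanyl group, and the range is kept wide. Compound 4 is estimated at 1 nM, between 0.3 nM and 3.5 nM.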

Compound 4, inhibition constant: 0.5 nM
Beside the measured number, compound 4's estimate is 2.0-fold (0.30 log units) above it, within the range that was stated.
By their numbers in this assay, from the lowest: compounds 2, 4, 3 and 1 (each within the scatter of the next, the first and the last beyond it).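

For the compounds shown here, the benzylsulfanyl group, the first sulfur-linked group with an aromatic ring at this aromatic carbon, holds the number in this assay: a 1.2-fold lower number from compound 3 to compound 4 (0.08 log units; within the scatter) and no change at the digits printed from compound 2 to compound 4 (within the scatter) both stay within the scatter. Against butyl(methyl)amino, the change gives a 2.4-fold lower number from compound 1 to compound 4 (0.38 log units; beyond the scatter), the same modest size as a 2.4-fold lower number from compound 1 to compound 2 (0.38 log units; beyond the scatter). No evidence available here accounts for these steps.

From the compounds shown here alone, whether sulfur itself matters stays open, and benzyloxy on this carbon would test that. Going by these compounds, how a primary amine or a carboxylic acid at this position would read also remains unknown.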